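The compounds below may be only part of what the source reports. "The series", "measured", "known", "first", "only" and "open" are said of these compounds alone.

Measured compounds:
Compound 1 `CC1CCN(c2c(S(=O)(=O)c3ccccc3)cnc3cc(Cl)ccc23)CC1` gives 93%.
Compound 2 `Cc1ccc(S(=O)(=O)c2cnc3cc(Cl)ccc3c2N2CCC(C)CC2)cc1` gives 94%.
Compound 3 `Cc1ccc(S(=O)(=O)c2cnc3cc(F)ccc3c2N2CCC(C)CC2)cc1` gives 88%.

In an assay on isolated protein for displacement of a labelled ligand from metabotropic glutamate receptor 5 (Homo sapiens), with a stated time of 60 min, tested at 1 uM (on this read-out lower numbers stand for less inhibition and higher numbers for more inhibition at the one concentration tested (going by the name of the read-out)), compound 2 stands highest of the three numbers, but the steps of a number 1 percentage points higher from compound 1 to compound 2 (within the scatter) and a number 6 percentage points lower from compound 2 to compound 3 (within the scatter) both lie within the scatter, so the three compounds cannot be ranked against each other. Compound 4 `Cc1ccc(S(=O)(=O)c2cnc3cc(Cl)ccc3c2N2CCC(C)CC2)cc1C` differs from compound 2 by methyl in place of hydrogen on an aromatic carbon. Going by the values given here, only one measured step is of the same kind, namely a number 1 percentage points higher from compound 1 to compound 2 (within the scatter), which added a methyl on an aromatic carbon and stayed within the scatter. Among the compounds with values here, no step of the present kind is measured at this place. With compound 2 already near the top of the scale, little room remains upward, and the expected step is a number 2 percentage points lower from compound 2 to compound 4 (within the scatter), none beyond the scatter. Compound 4 is therefore estimated at 92%, within a range from 84% to 98%.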

Compound 4, a percentage reported as inhibition, at one concentration (the size of the read-out at that concentration, not a potency): 86%
The estimate for compound 4 lay 6 percentage points above the measured number; the range from low to high includes it.
By their numbers in this assay, from the lowest: compounds 4, 3, 1 and 2 (each within the scatter of the next).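

In this assay, the 3,4-dimethylphenyl group of compound 4 carries a new methyl on an aromatic carbon, ortho to a methyl group, and the step reads a number 8 percentage points lower from compound 2 to compound 4 (within the scatter). Counted from the unsubstituted phenyl, the step reads a number 7 percentage points lower from compound 1 to compound 4 (within the scatter), so neither comparison shows a readable difference, and this position accepts the added methyl within the listed compounds. Nothing measured here explains the result. From the compounds shown here alone, whether a methoxy group, an amine or a longer chain at this position would also stay within the scatter remains open. Readings at one concentration also leave the potencies of these compounds unknown.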